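A few compounds are considered here, and "the series" means these few. Any claim that something is new, unique, unknown or untested is made for them only; others in the source may bear on it.

Measured compounds: compound 1 `CCOc1ccc(-c2c(C#N)c(N)nc(SCc3ccn[nH]3)c2C#N)cc1`, in an assay on CHO cells for displacement of a labelled ligand from adenosine receptor A1 (Homo sapiens), read by scintillation counting, with a stated time of 90 min (on this read-out higher numbers stand for weaker inhibition and lower numbers for stronger inhibition), compound 1 gives 21 nM; compound 2 `C=CCOc1ccc(-c2c(C#N)c(N)nc(SCC(N)=O)c2C#N)cc1`, compound 2 gives 323 nM; compound 3 `CC(C)COc1ccc(-c2c(C#N)c(N)nc(SCC(N)=O)c2C#N)cc1`, compound 3 gives 603 nM.

Compound 3 has the highest number of the three, yet it sits close to compound 2, while compound 1 lies far below both. The step to compound 4 `CCOc1ccc(-c2c(C#N)c(N)nc(SCC(N)=O)c2C#N)cc1` is methyl in place of isopropyl on a saturated chain carbon bound to an oxygen on an aromatic ring. The one measured step that bears on this position, a 1.9-fold higher number from compound 2 to compound 3 (0.27 log units; within the scatter), lies within the scatter, so the alkoxy chain has shown little leverage here. Compound 1 carries the same ethoxy group as compound 4 but differs elsewhere, so its value cannot be read as a step. The author therefore expects a small step, a 1.7-fold lower number from compound 3 to compound 4 (0.24 log units; within the scatter), for compound 4. Compound 4 is estimated at 350 nM, within 120 nM to 1000 nM.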

Compound 4, inhibition constant: 345 nM
Beside the measured number, compound 4's estimate is 1.0-fold (0.01 log units) above it, and the stated range covers the measured number.
By their numbers in this assay, from the lowest: compound 1; then compounds 2, 4 and 3 (each within the scatter of the next).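

In this assay, isobutoxy to ethoxy gives a 1.7-fold lower number from compound 3 to compound 4 (0.24 log units; within the scatter) and methyl in place of vinyl gives a 1.1-fold higher number from compound 2 to compound 4 (0.03 log units; within the scatter), so across these three chains on the oxygen the read-out stays within the scatter. Carbamoyl in place of 1H-pyrazol-5-yl on a saturated chain carbon bound to a sulfur, with the ethoxy group held constant, gives a 16-fold higher number from compound 1 to compound 4 (1.22 log units; beyond the scatter), so the large difference in this set belongs to that place. No evidence here accounts for either finding.

As far as these compounds go, whether a longer chain or an amine on the oxygen side would stay within the scatter remains open. So does how a carboxylic acid would read in place of the carbamoyl on the sulfur side.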